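This account rests on a few compounds, and the source may have more. Where it says the series, first, only, none or still open, it means among the compounds named here.

Measured so far in a functional assay on MDA-MB-435 cells (Homo sapiens); a higher number here means a weaker inhibitor of growth, a lower number a stronger inhibitor of growth:

compound 1 `Cc1cc(C)c2c(O)cc(-c3ccc(Cl)cc3)nc2n1`: 4070 nM.
compound 2 `COc1cccc(-c2cc(O)c3c(C)cc(C)nc3n2)c1`: < 10 nM.
compound 3 `Cc1ccnc2nc(-c3ccc(Cl)cc3)cc(O)c12`: 759 nM.

This assay reports for compound 2 only (the limit of < 10 nM in this assay, at which 1 of the 3 values shown sits), so its value is a limit of the assay and not a number.

Compound 1 and compound 3 share a core and differ in one place, (hydrogen in place of methyl on an aromatic carbon). That single change gave a 5.4-fold lower number from compound 1 to compound 3 (0.73 log units; beyond the scatter), so removing the methyl went with a stronger inhibitor of growth.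

Compound 4 `COc1cccc(-c2cc(O)c3c(C)ccnc3n2)c1` has not yet been measured in this assay. Among the measured compounds shown here, it differs from compound 2 by hydrogen in place of methyl on an aromatic carbon, which is the same change as the one from compound 1 to compound 3. How the core of compound 2 differs from the core of compound 1 is not broken down here.

Since compound 2 already sits at a limit, a step of the earlier size cannot be seen in full. Compound 4 is expected to show a step that the limit leaves unreadable from compound 2 to compound 4, resting on the step of a 5.4-fold lower number from compound 1 to compound 3 (0.73 log units; beyond the scatter) and on the limit for compound 2. Compound 4 is estimated at 3 nM, with a range from 0.5 nM to 15 nM, most likely again reported only as a limit.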

Compound 4, concentration for 50% growth inhibition: < 10 nM
Compound 4 ended at the assay's limit; the forecaster's own chance of this, stated with the estimate: 70%; the middle value lies beyond the limit too.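

In this assay, no size can be read for the step between compound 2 and compound 4, because both compounds sit at the same limit of the assay rather than at a number: the limit of < 10 nM in this assay, at which 2 of the 4 values shown sit.

The compounds shown leave open how strong compound 2 and compound 4 truly are, and whether replacing methyl with hydrogen changes growth inhibition on this core.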